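A few compounds are considered here, and "the series" means these few. Any claim that something is new, unique, unknown or untested is made for them only; others in the source may bear on it.

Working notes on the thiadiazole glycoside series.

Compound 2 `CCCCCCCC(=O)Nc1nnc(S[C@@H]2O[C@H](CO)[C@H](O)[C@H](O)[C@H]2O)s1` is recorded in a functional assay on DU-145 cells (Homo sapiens) for cytotoxicity, read by MTT assay, with a stated time of 24 h (on this read-out higher numbers stand for weaker inhibition and lower numbers for stronger inhibition), as "not active" (no number reported), with no number attached. The acetylated analogues do give numbers: compound 1 `CCCCCCCCCCCCCCCCCC(=O)Nc1nnc(S[C@@H]2O[C@H](COC(C)=O)[C@H](OC(C)=O)[C@H](OC(C)=O)[C@H]2OC(C)=O)s1` gives 31200 nM in this assay, and compound 3 `CCCCCCCCCC(=O)Nc1nnc(S[C@@H]2O[C@H](COC(C)=O)[C@H](OC(C)=O)[C@H](OC(C)=O)[C@H]2OC(C)=O)s1` gives 34400 nM. Among the measured compounds shown here, the one measured step among them, a 1.1-fold higher number from compound 1 to compound 3 (0.04 log units; within the scatter), shows that lengthening the acyl chain within the acetylated set leaves the read-out essentially unchanged.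

Compound 4 `CCCCCCCC/C=C\CCCCCCCC(=O)Nc1nnc(S[C@@H]2O[C@H](CO)[C@H](O)[C@H](O)[C@H]2O)s1` arises from compound 2 by dec-1-en-1-yl in place of hydrogen on a saturated chain carbon, seven bonds along the chain from a carbonyl carbon. For the measured compounds named here, the only step that bears on it is the chain-lengthening step from compound 1 to compound 3, which was within scatter, so no shift beyond scatter is expected from the chain change itself; compound 2 carries the same free sugar and gave no number. Compound 4 is therefore expected to remain weak in this assay, around 50000 nM, plausibly between 20000 nM and 150000 nM, with a real chance that only a limit is reported.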

Compound 4, half-maximal inhibitory concentration: "not active" (no number reported)
For compound 4 the study gives words and no number, and the estimate cannot be compared.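

Compound 2 and compound 4 are both recorded as not active in this assay, without a number, so no step can be read between them. No supporting measurement bears on this result. The compounds shown leave open whether dec-1-en-1-yl changes the read-out on the free sugar.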